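Swapping the aryl group on a carbamate in a PANC-1 series

A few compounds are considered here, and "the series" means these few. Any claim that something is new, unique, unknown or untested is made for them only; others in the source may bear on it.

Measured compounds:
compound 1 `CC(C)=CCC1Cc2c(OC(=O)Nc3ccc(F)cc3)cc(=O)n(CCCO)c2CC1(C)C` gives 71.2%
compound 2 `CC(C)=CCC/C(C)=C/CC1Cc2c(OCCCNC(=O)c3cccs3)cc(=O)n(CCCO)c2CC1(C)C` gives 72.8%
compound 3 `COc1cccc(NC(=O)Oc2cc(=O)n(CCCO)c3c2CC(C/C=C(\C)CCC=C(C)C)C(C)(C)C3)c1` gives 47%

In a functional assay on PANC-1 cells (Homo sapiens) for inhibition, read by MTT assay, with a stated time of 24 h, tested at 10 uM (on this read-out higher numbers stand for more inhibition at the one concentration tested (going by the name of the read-out) and lower numbers for less inhibition), compound 3 stands lowest of the three, with compound 1 nearest and compound 2 furthest from it, both beyond the scatter. Compound 4 `CC(C)=CCC/C(C)=C/CC1Cc2c(OC(=O)Nc3ccc(F)cc3)cc(=O)n(CCCO)c2CC1(C)C` differs from compound 3 by one change: 4-fluorophenyl in place of 3-methoxyphenyl on an amide-type nitrogen. No measured step touches this change directly; the only step shown, a number 25.8 percentage points lower from compound 2 to compound 3 (beyond the scatter), concerns a different part of the molecule. Compound 1, which already carries the (4-fluorophenyl)carbamoyl group on a shorter chain, sits well above compound 3. On that basis compound 4 is expected to rise, by about a number 18 percentage points higher from compound 3 to compound 4 (beyond the scatter), to an estimated 65% with a range from 45% to 80%.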

Compound 4, a percentage reported as inhibition, at one concentration (the size of the read-out at that concentration, not a potency): 43.9%
For compound 4 the middle estimate is 21.1 percentage points above the measured one, and the stated range ends above it.
By their numbers in this assay, from the lowest: compounds 4 and 3 (each within the scatter of the next); then compounds 1 and 2 (each within the scatter of the next).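

In this assay, among these compounds, 4-fluorophenyl and 3-methoxyphenyl on the amide-type nitrogen cannot be told apart (a number 3.1 percentage points lower from compound 3 to compound 4 (within the scatter)), so this change shows no effect in this pair. The larger steps lie elsewhere: adding 3-methylbut-2-en-1-yl in place of hydrogen on the saturated chain carbon (a number 27.3 percentage points lower from compound 1 to compound 4 (beyond the scatter)), and placing (4-fluorophenyl)carbamoyl in place of 3-(((thiophen-2-yl)carbonyl)amino)propyl on the oxygen (a number 28.9 percentage points lower from compound 2 to compound 4 (beyond the scatter)). No available evidence explains these results. From the compounds shown here alone, whether an amine or a carboxylic acid on the aryl ring would change the reading remains open.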